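Swapping the phenoxy of compound 1 for a methoxyphenyl

The source may hold more compounds than are shown below. What is called first, only, known or untested is meant among the compounds shown, and "the series" means these compounds.

Going by the values given here, compound 1 `Cc1ccccc1-n1nc(C)c2c1NC(=O)[C@H](C)S[C@@H]2c1ccc(Oc2ccccc2)cc1` is the only compound here with a number: in an assay on isolated protein for agonist activity at Bile acid receptor (Homo sapiens), read by AlphaScreen, with a stated time of 30 min (on this read-out higher numbers stand for an effect only at larger amounts of compound and lower numbers for an effect already at smaller amounts), compound 1 gives 1300 nM. Two related compounds carry a methyl ester on a directly attached aryl ring: compound 2 `COC(=O)c1cccc(-c2ccc([C@H]3S[C@@H](C)C(=O)Nc4c3c(C)nn4-c3ccccc3C)cc2)c1` is reported in this assay as "not active" (no number reported), and compound 3 `COC(=O)c1ccc(-c2ccc([C@H]3S[C@@H](C)C(=O)Nc4c3c(C)nn4-c3ccccc3C)cc2)cc1` as "not active" (no number reported), with no number for either. Compound 4 `COc1ccccc1-c1ccc([C@H]2S[C@@H](C)C(=O)Nc3c2c(C)nn3-c2ccccc2C)cc1` also carries a directly attached aryl ring, differing from compound 1 by 2-methoxyphenyl in place of phenoxy on an aromatic carbon, on an aromatic carbon para to a large group. Since compound 2 and compound 3 gave no number, the expected step of a 3.8-fold higher number from compound 1 to compound 4 (0.59 log units; beyond the scatter) is toward larger amounts, beyond the scatter. Compound 4 is estimated at 5000 nM, within 1500 nM to 20000 nM.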

Compound 4, half-maximal effective concentration: 1100 nM
Compound 4: middle estimate off by 4.5-fold (0.66 log units), on the high side; measured number below the stated range.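

In this assay the swap gives a 1.2-fold lower number from compound 1 to compound 4 (0.07 log units; within the scatter) and so shows that 2-methoxyphenyl and phenoxy read alike on this aromatic carbon. A directly attached aryl ring can therefore stand here and still give a number, which compound 2 and compound 3, both reported as not active with their methyl esters, did not show. No measurement shown explains why the two groups read alike.

As far as these compounds go, it remains open whether a carboxylic acid or an amine in place of the methoxy group on this attached ring would give a number.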